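Propyl for Methylsulfanyl on Two Related Cores

The source may report more compounds than this note shows. Statements on the series, on what has been measured and on what is new or still open speak of the compounds shown alone.

Compound 1, `CCOC(=O)C1=C(C)NC(=O)NC1c1ccc(SC)cc1`, gives 2.7 ug/mL in a functional assay on NCI/ADR-RES cells (Homo sapiens) for inhibition, read by sulforhodamine B assay, with a stated time of 48 h; on this read-out lower numbers stand for stronger inhibition of growth and higher numbers for weaker inhibition of growth.
Compound 2, `CCCc1ccc(C2NC(=S)NC(C)=C2C(=O)OCC)cc1`, gives 40.3 ug/mL in this assay.
Compound 3, `CCOC(=O)C1=C(C)NC(=S)NC1c1ccc(SC)cc1`, gives 35.7 ug/mL in this assay.

Compounds 2 and 3 share one core and differ only in the group carried on the aromatic ring: propyl in place of methylsulfanyl on an aromatic carbon. That swap made a 1.1-fold higher number from compound 3 to compound 2 (0.05 log units; within the scatter), so in this pair the two groups behave alike within the reach of the measurement.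

Compound 1 carries the methylsulfanyl group on a different core; the difference between the two cores is not broken down here. Its number in this assay is the lowest of the three, and the gap to compound 3 lies well beyond the scatter, so the core of compound 1 appears to be what separates it from compounds 2 and 3.

Compound 4, `CCCc1ccc(C2NC(=O)NC(C)=C2C(=O)OCC)cc1`, has not yet been measured. It is built from compound 1 by the same change seen between compounds 3 and 2: propyl in place of methylsulfanyl on an aromatic carbon. The place of the change is the same in both pairs, word for word, so the change is the same. Because that change gave a 1.1-fold higher number from compound 3 to compound 2 (0.05 log units; within the scatter), the expectation is that compound 4 will stay close to compound 1, with an estimated step of a 1.1-fold higher number from compound 1 to compound 4 (0.05 log units; within the scatter). Compound 4 is therefore estimated at 3 ug/mL, most likely between 1.3 ug/mL and 7 ug/mL.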

Compound 4, concentration for 50% growth inhibition: 20.9 ug/mL
Estimate against measurement, compound 4: 7.0-fold (0.84 log units) below, and the stated range ends below it.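

In this assay, the swap of methylsulfanyl for propyl does not carry over unchanged from one core to the other. On the core of compound 1 it gives a 7.7-fold higher number from compound 1 to compound 4 (0.89 log units; beyond the scatter), while on the core shared by compound 2 and compound 3 the two groups could not be told apart, and the two steps clearly disagree: the same change on two cores in this assay, a 1.1-fold higher number (0.05 log units; within the scatter) from compound 3 to compound 2 and a 7.7-fold higher number (0.89 log units; beyond the scatter) from compound 1 to compound 4, 6.9-fold (0.84 log units) apart, beyond the scatter of two such steps. A step read on one of these cores is therefore a poor guide to the same change on the other, although this rests on a single pair for each core and does not show why the cores respond differently or how the change would behave on a third core.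

The compounds shown carry only methylsulfanyl and propyl at this place on the aromatic ring, and it remains open whether a longer chain such as butyl, a shorter one such as ethyl, or a different group such as methoxy or an amine would track compound 1 or compound 4 on the core of compound 1. From the compounds shown here alone, it also remains open whether the disagreement between the two cores extends to other groups at this place or to other cell lines.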